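Aryl variation on the shared core: chloro to nitro

The compounds below may be only part of what the source reports. "The series", "measured", "known", "first", "only" and "open" are said of these compounds alone.

Compound 2 `O=c1c2ccccc2[se]n1-c1nnc(-c2ccccc2Cl)s1` gives 10100 nM in a functional assay on A549 cells (Homo sapiens) for antiproliferative activity, read by CCK-8 assay, with a stated time of 48 h (on this read-out higher numbers stand for weaker inhibition and lower numbers for stronger inhibition), the lowest number among the three measured compounds. Compound 1 `O=c1c2ccccc2[se]n1-c1nnc(-c2ccc(F)cc2)s1` gives 21100 nM and compound 3 `Cc1cccc(-c2nnc(-n3[se]c4ccccc4c3=O)s2)c1` gives 14800 nM. The step of a 2.1-fold lower number from compound 1 to compound 2 (0.32 log units; beyond the scatter) is modest and beyond the scatter, while the step of a 1.5-fold higher number from compound 2 to compound 3 (0.17 log units; within the scatter) and the step of a 1.4-fold lower number from compound 1 to compound 3 (0.15 log units; within the scatter) stay within it. Compound 4 `O=c1c2ccccc2[se]n1-c1nnc(-c2ccccc2[N+](=O)[O-])s1` carries nitro in place of chloro on an aromatic carbon. For the measured compounds named here, no measured step introduces a nitro group, so the aryl exchanges above are the only guide, and every one of them was small. In this assay the step of a 1.2-fold higher number from compound 2 to compound 4 (0.07 log units; within the scatter) is therefore expected to remain within or close to the scatter, with no clear direction. Compound 4 is estimated at 12000 nM, between 6000 nM and 25000 nM.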

Compound 4, half-maximal inhibitory concentration: 11400 nM
The estimate for compound 4 lay 1.1-fold (0.02 log units) above the measured number, and the stated range covers the measured number.
By their numbers in this assay, from the lowest: compounds 2, 4, 3 and 1 (each within the scatter of the next, the first and the last beyond it).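

In this assay, a 1.1-fold higher number from compound 2 to compound 4 (0.05 log units; within the scatter), so the two compounds cannot be told apart at this place on the aromatic ring, ortho to a large group. Unlike the earlier aryl exchanges, this step keeps the place fixed and changes only the group: a single chlorine gives way to nitro, with more heavy atoms and two hydrogen-bond acceptors, and the number stays within the scatter. No supporting data are available to explain this outcome. On these data alone, whether an amine or a carboxylic acid at this place would also stay within the scatter remains open. So does the effect of nitro elsewhere on the aryl ring.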